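Replacing the Oxopiperazine of Compound 2 with a Methylpiperidine

A few compounds are considered here, and "the series" means these few. Any claim that something is new, unique, unknown or untested is made for them only; others in the source may bear on it.

Of the compounds shown here, three have been measured in an assay on HEK293 cells for inhibition of acid ceramidase (Homo sapiens), read by fluorescence, with stated times of 10 min and 3 h; on this read-out higher numbers stand for weaker inhibition and lower numbers for stronger inhibition. Compound 1 `CC(C)CNC(=O)n1c(=O)oc2ccc(C3CCN(C)CC3)cc21` gives 295 nM, compound 2 `CN1CCN(c2ccc3c(c2)oc(=O)n3C(=O)NCCCCc2ccccc2)CC1=O` gives 92 nM, and compound 3 `CCCCCNC(=O)n1c(=O)oc2cc(-c3ccc(F)cc3)ccc21` gives 60 nM. Compound 2 sits second highest of the three: its number lies within the scatter of compound 3, while compound 1 stands beyond the scatter, at a higher number. Compound 4 `CN1CCC(c2ccc3c(c2)oc(=O)n3C(=O)NCCCCc2ccccc2)CC1` is not yet measured; it differs from compound 2 in one place: 1-methylpiperidin-4-yl in place of 4-methyl-3-oxopiperazin-1-yl on an aromatic carbon. For the measured compounds named here, no measured pair shows this change directly. Compound 1 already carries the 1-methylpiperidin-4-yl group, and its value of 295 nM hints at a somewhat higher number, though its other parts differ. Compound 4 is therefore expected in this assay at 150 nM, within 50 nM to 400 nM. The expected step of a 1.6-fold higher number from compound 2 to compound 4 (0.21 log units; within the scatter) is small and may not exceed the scatter.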

Compound 4, half-maximal inhibitory concentration: 129 nM
Beside the measured number, compound 4's estimate is 1.2-fold (0.07 log units) above it; the measured number falls inside the stated range.
By their numbers in this assay, from the lowest: compounds 3, 2 and 4 (each within the scatter of the next, the first and the last beyond it); then compound 1.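

In this assay, 1-methylpiperidin-4-yl in place of 4-methyl-3-oxopiperazin-1-yl on this aromatic carbon gives a 1.4-fold higher number from compound 2 to compound 4 (0.15 log units; within the scatter) and so stays within the scatter. For the compounds shown here, this pair is the first direct reading of the change, and it shows that the ring carbonyl and second ring nitrogen of the leaving group can go without a shift beyond the scatter. Nothing available explains why the two groups read alike. From the compounds shown here alone, whether a morpholine or a piperidine lacking the methyl group would read similarly on this carbon remains open.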